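The compounds below may be only part of what the source reports. "The series", "measured", "known", "first", "only" and "open" are said of these compounds alone.

Measured so far in a functional assay on MDA-MB-231 cells (Homo sapiens) for inhibition, read by MTT assay, with a stated time of 48 h; on this read-out higher numbers stand for weaker inhibition and lower numbers for stronger inhibition:

- compound 1 `CCn1c(/C=C2\SC(=O)N(CC(=O)N3CCOCC3)C2=O)nc2ccccc21`: in this assay compound 1 gives > 50000 nM, a limit of the assay.
- compound 2 `CCn1c(/C=C2\SC(=O)N(CC(=O)Nc3cc(C(C)(C)C)on3)C2=O)nc2ccccc21`: in this assay compound 2 gives > 50000 nM, a limit of the assay.
- compound 3 `CC1CN(C(=O)CN2C(=O)S/C(=C\c3nc4ccccc4n3C(C)C)C2=O)CC(C)O1`: in this assay compound 3 gives > 50000 nM, a limit of the assay.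

Compound 3 therefore stands at the limit of this assay, as do the other two measured compounds, and no number separates any of them. The step to compound 4 `CCn1c(/C=C2\SC(=O)N(CC(=O)N3CC(C)OC(C)C3)C2=O)nc2ccccc21` is hydrogen in place of methyl on a saturated chain carbon bound to an aromatic nitrogen and a saturated chain carbon. For the measured compounds named here, the only step between measured compounds that differ in one place, a step that the two limits leave unreadable from compound 1 to compound 2, is unreadable, both of its ends being limits; it concerns the group on a carbonyl carbon, not the chain on the aromatic nitrogen, so it does not bear on the present change. Going by the values given here, because of the limit of > 50000 nM in this assay, at which 3 of the 3 values shown sit, no size of step can be drawn from the measured compounds, and nothing among them points in a direction for the change from compound 3 to compound 4. The expectation is that compound 4 will likewise report only a limit in this assay. The step expected in this assay is a step that the limit leaves unreadable from compound 3 to compound 4. Compound 4 is estimated at 80000 nM in this assay, within a range of 30000 nM to 300000 nM.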

Compound 4, half-maximal inhibitory concentration: > 50000 nM
Compound 4 ended at the assay's limit (the forecaster's own chance of this, stated with the estimate: 85%); the middle value lies beyond the limit too.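

Compound 4 sits at the limit in this assay, as do compound 1, compound 2 and compound 3, so none of the steps from those three compounds to compound 4 can be read: the limit of > 50000 nM in this assay, at which 4 of the 4 values shown sit. The compounds shown leave open how large any of these changes is, and what the chain on the aromatic nitrogen or the group on the carbonyl carbon does to a value inside the range of this assay.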